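The source may report more compounds than this note shows. Statements on the series, on what has been measured and on what is new or still open speak of the compounds shown alone.

Measured compounds in an ADME assay on Vero cells (Chlorocebus sabaeus) for cytotoxicity, read by resazurin assay, with a stated time of 3 days; a lower number here means a stronger inhibitor, a higher number a weaker inhibitor:

- Compound 1, `CN(C)c1cc2[nH]c(C3CCCCC3)nc2cc1NC(=O)c1ccco1` — in this assay compound 1 gives > 100 ug/mL, which is a limit of the assay and not a number.
- Compound 2, `O=C(CCc1ccccc1)Nc1cc2nc(C3CCCCC3)[nH]c2cc1N1CCCC1` — in this assay compound 2 gives > 100 ug/mL, again a limit of the assay and not a number.

Where compound 1 stands on the numbers shown: only a limit is known for it, and the one other value shown is likewise a limit; both sit together at the limit of > 100 ug/mL in this assay, at which 2 of the 2 values shown sit. Within the data shown here, no step between measured compounds can be drawn from these two values, since neither is a number.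

Compound 3, `CN(C)c1cc2[nH]c(C3CCCCC3)nc2cc1NC(=O)OCC(F)(F)F`, is not yet measured in this assay. It differs from compound 1 by 2,2,2-trifluoroethoxy in place of furan-2-yl on a carbonyl carbon. Among the measured compounds shown here, with no measured step in the set and both known values at the limit, no direction can be read from the numbers; the step from compound 1 to compound 3 in this assay is expected to be none beyond the scatter, and in practice the assay is expected to report a limit again.

Compound 3 is therefore estimated at 120 ug/mL, with a range from 50 ug/mL to 300 ug/mL; this estimate means a step that the limit leaves unreadable from compound 1 to compound 3.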

Compound 3, half-maximal inhibitory concentration: > 100 ug/mL
Compound 3: a limit, no number; the forecaster's own chance of this, stated with the estimate: 75%; the middle value is on the limit's open side.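

In this assay compound 3 gives > 100 ug/mL as a limit of the assay and not a number. Compound 1 also stands at a limit, so no step can be read between compound 1 and compound 3: the limit of > 100 ug/mL in this assay, at which 3 of the 3 values shown sit.

The compounds shown leave open where any of them lies past that limit, and whether 2,2,2-trifluoroethoxy in place of furan-2-yl changes the read-out at all.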